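Does a Benzyl Group Wake an Inactive Series?

The source may report more compounds than this note shows. Statements on the series, on what has been measured and on what is new or still open speak of the compounds shown alone.

- compound 1 `O=C(NCc1ccc(F)cc1)c1nc(Br)c2cccnc2c1NCCO` gives > 20000 nM as a limit
- compound 2 `CNc1c(C(=O)NCc2ccc(F)cc2)nc(Br)c2cccnc12` gives > 20000 nM as a limit

In a functional assay on HCT-116 cells (Homo sapiens) for cytotoxicity, read by MTT assay, with a stated time of 72 h (a higher number here means a weaker inhibitor, a lower number a stronger inhibitor), compound 2 stands at > 20000 nM as a limit of the assay and not a number. Compound 3 `O=C(NCc1ccc(F)cc1)c1nc(Br)c2cccnc2c1NCc1ccccc1` turns its methylamino into benzylamino (phenyl in place of hydrogen on a saturated chain carbon bound to a nitrogen on an aromatic ring). Within the data shown here, the only measured step is a step that the two limits leave unreadable from compound 1 to compound 2 and it gives no size to carry over, as the limit of > 20000 nM in this assay, at which 2 of the 2 values shown sit, makes plain. The estimated move is an at least 1.3-fold lower number from compound 2 to compound 3 (0.12 log units; that floor lies within the scatter) as a small expected shift towards a stronger inhibitor. Compound 3 is estimated at 15000 nM in this assay with 5000 nM to 30000 nM as the expected range.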

Compound 3, half-maximal inhibitory concentration: > 20000 nM
Compound 3 was reported as a limit; the forecaster's own chance of this, stated with the estimate: 60%; middle value at least 1.3-fold (0.12 log units) away from the limit.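

In this assay, among these compounds, compound 3 gives > 20000 nM, again a limit and not a number, so no step from compound 1 or compound 2 to compound 3 can be read. The compounds shown leave open whether benzylamino truly differs from methylamino or from the hydroxyethylamino chain of compound 1.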